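Swapping a phenethyl arm for a thiazole on a receptor agonist

A few compounds are considered here, and "the series" means these few. Any claim that something is new, unique, unknown or untested is made for them only; others in the source may bear on it.

Measured so far:
- compound 1, `CCCCNc1nc(N)nc2ccn(CCCc3ccccc3)c12`: 3.78 uM
- compound 2, `CCCCNc1nc(N)nc2ccn(Cc3ccsc3)c12`: > 25 uM

Within the data shown here, in an assay on HEK293 cells for agonist activity at Toll-like receptor 8 (Homo sapiens), read by a luciferase reporter, with a stated time of 6 h (on this read-out higher numbers stand for an effect only at larger amounts of compound and lower numbers for an effect already at smaller amounts), compound 1 gives 3.78 uM, the only actual number among the two values shown. Compound 2 reaches only a limit of this assay, > 25 uM, which means no effect was seen up to the highest amount tested. The step of an at least 6.6-fold higher number from compound 1 to compound 2 (0.82 log units; beyond the scatter) therefore marks a weakening, and its size is set by the limit of > 25 uM in this assay, at which 1 of the 2 values shown sits.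

Compound 3, `CCCCNc1nc(N)nc2ccn(Cc3nccs3)c12`, is not yet measured. It differs from compound 1 by 1,3-thiazol-2-yl in place of phenethyl on a saturated chain carbon bound to an aromatic nitrogen. Among the measured compounds shown here, this change resembles the one from compound 1 to compound 2: both replace the phenethyl with a smaller five-membered aromatic ring on a saturated chain carbon bound to an aromatic nitrogen. Because an at least 6.6-fold higher number from compound 1 to compound 2 (0.82 log units; beyond the scatter) went beyond the scatter toward weaker activity, a similar loss is expected here.

Compound 3 is expected to give 20 uM in this assay, within a range of 5 uM to 60 uM. The expected step is a 5.3-fold higher number from compound 1 to compound 3 (0.72 log units; beyond the scatter), with a fair chance that only a limit is reported.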

Compound 3, minimum effective concentration: 2.27 uM
The estimate for compound 3 lay 8.8-fold (0.95 log units) above the measured number; measured number below the stated range.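

At this position, size alone does not decide the outcome: in this assay, the step of a 1.7-fold lower number from compound 1 to compound 3 (0.22 log units; within the scatter) shows that the 1,3-thiazol-2-yl, with 5 heavy atoms, can stand in for the phenethyl, with 8, with no difference that can be told from the usual scatter. Compound 2 had suggested that giving up the phenethyl for a five-membered aromatic ring costs activity, but the step of an at least 11-fold lower number from compound 2 to compound 3 (1.04 log units; beyond the scatter) shows that the identity of the five-membered ring matters greatly, even though both rings are small and sit in the same place on a saturated chain carbon bound to an aromatic nitrogen. The true size of that gap remains unknown, and the printed step is only a minimum, set by a limit: the limit of > 25 uM in this assay, at which 1 of the 3 values shown sits.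

The thiophen-3-yl and the 1,3-thiazol-2-yl differ both in the ring's atoms and in how the ring is attached, so these compounds cannot show which of the two differences accounts for the gap. Going by these compounds, how a pyridine ring, a thiophen-2-yl or an amine would fare at this place also remains open, so the three compounds cannot yet define a general rule for this arm.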